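Hydrogen in place of bromo on the shared core

The source may hold more compounds than are shown below. What is called first, only, known or untested is meant among the compounds shown, and "the series" means these compounds.

In a functional assay on MKN-45 cells (Homo sapiens) for cytotoxicity (on this read-out higher numbers stand for weaker inhibition and lower numbers for stronger inhibition), compound 1 `COc1ccc(S(=O)(=O)N2CCc3cccc(NS(=O)(=O)c4ccc(F)cc4)c32)cc1` gives 890 nM. Compound 2 `COc1ccc(S(=O)(=O)N2CCc3cccc(NC(=O)Oc4ccccc4)c32)cc1` gives > 10000 nM, which is a limit of the assay and not a number. Compound 3 `COc1ccc(S(=O)(=O)N2CCc3cc(Br)cc(NC(=O)c4ccco4)c32)cc1` gives 78 nM, the lowest number shown, against 890 nM for compound 1.

Compound 4 `COc1ccc(S(=O)(=O)N2CCc3cccc(NC(=O)c4ccco4)c32)cc1` differs from compound 3 by hydrogen in place of bromo on an aromatic carbon. Within the data shown here, the one measured step, phenoxycarbonyl in place of (4-fluorophenyl)sulfonyl on a nitrogen on an aromatic ring, is an at least 11-fold higher number from compound 1 to compound 2 (1.05 log units; beyond the scatter). That step is large, but it bears only indirectly, as it changes the group on the nitrogen and not the bromo position. Among the measured compounds shown here, no measured pair isolates the loss of bromo, so its direction is open and the range must stay wide.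

Compound 4 keeps the ((furan-2-yl)carbonyl)amino group of compound 3, which gives 78 nM, so the expectation stays close to that value. The expected step is a 1.5-fold higher number from compound 3 to compound 4 (0.19 log units; within the scatter), with a slight lean towards a higher number and no firm change beyond the scatter. For compound 4 the estimated value is 120 nM, with an expected range from 25 nM to 600 nM in this assay.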

Compound 4, half-maximal inhibitory concentration: 10.7 nM
Estimate against measurement, compound 4: 11-fold (1.05 log units) above; measured number below the stated range.
By their numbers in this assay, from the lowest: compound 4; then compound 3; then compound 1. At a limit, above all of these: compound 2.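

In this assay the aromatic carbon para to a fused ring and meta to the ((furan-2-yl)carbonyl)amino group can now be read on its own, and the change to hydrogen gives a 7.3-fold lower number from compound 3 to compound 4 (0.86 log units; beyond the scatter), so bromo is not needed at this position for a low number on this core. With hydrogen at that carbon, the group on the nitrogen can also be compared, with an 83-fold lower number from compound 1 to compound 4 (1.92 log units; beyond the scatter) on (furan-2-yl)carbonyl in place of (4-fluorophenyl)sulfonyl, and an at least 930-fold lower number from compound 2 to compound 4 (2.97 log units; beyond the scatter) on furan-2-yl in place of phenoxy on the carbonyl carbon, which makes compound 4 the lowest of the series and both of these steps large where the bromo step is modest. The step from the phenoxycarbonyl compound gives only a bound on its size, as compound 2 stands at a limit of the assay and not at a number: the limit of > 10000 nM in this assay, at which 1 of the 4 values shown sits.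

With only bromo and hydrogen shown at this carbon, it stays open whether a smaller halogen such as fluoro, or a methyl or methoxy group, would follow hydrogen or bromo. It is also open whether the effect of bromo carries over to the (4-fluorophenyl)sulfonyl series of compound 1, since the pair shown holds only the (furan-2-yl)carbonyl group on the nitrogen.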